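This account rests on a few compounds, and the source may have more. Where it says the series, first, only, none or still open, it means among the compounds named here.

Of the compounds shown here, three of one shared core have been tested, and a fourth awaits its number. Compound 1 `CCOc1ccc(NC(=O)c2cc3cc(Br)ccc3oc2=O)cc1` carries a bromo group on the core and, in a functional assay on CCRF-CEM cells (Homo sapiens) for antiproliferative activity, read by fluorescence and resazurin assay, with a stated time of 48 h (on this read-out lower numbers stand for stronger inhibition and higher numbers for weaker inhibition), compound 1 gives 21800 nM. Compound 2 `CCOc1ccc(NC(=O)c2cc3cc([N+](=O)[O-])ccc3oc2=O)cc1` carries a nitro group in the same place and in this assay compound 2 gives 13200 nM. Going by the values given here, the single change between them is bromo in place of nitro on an aromatic carbon, and it made a 1.7-fold higher number from compound 2 to compound 1 (0.22 log units; within the scatter). Compound 3 `O=C(N/N=C/c1cccnc1)c1cc2cc([N+](=O)[O-])ccc2oc1=O` keeps the nitro group but differs from compound 2 on the other side of the core; how the two cores differ is not broken down here. In this assay compound 3 gives 17100 nM, a number that sits within the usual scatter of both compound 1 and compound 2, so no order among the three can be read from these values.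

Compound 4 `O=C(N/N=C/c1cccnc1)c1cc2cc(Br)ccc2oc1=O` is not yet measured. It differs from compound 3 by bromo in place of nitro on an aromatic carbon. Among the compounds with values here, this is the same change as the one from compound 2 to compound 1, made on the same place of the core. On the strength of that earlier step alone, the expected step is a 1.5-fold higher number from compound 3 to compound 4 (0.16 log units; within the scatter), because the measured step of a 1.7-fold higher number from compound 2 to compound 1 (0.22 log units; within the scatter) was small and within the scatter. The estimate for compound 4 in this assay is therefore 25000 nM, with a plausible range from 10000 nM to 60000 nM, resting on a single prior example of this change.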

Compound 4, half-maximal inhibitory concentration: 3710 nM
Compound 4: the middle estimate sits 6.7-fold (0.83 log units) above what was measured; measured number below the stated range.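

Bromo in place of nitro does not carry over unchanged from one core to the other in this assay: the same change on two cores in this assay, a 1.7-fold higher number (0.22 log units; within the scatter) from compound 2 to compound 1 and a 4.6-fold lower number (0.66 log units; beyond the scatter) from compound 3 to compound 4, 7.6-fold (0.88 log units) apart, beyond the scatter of two such steps. On the core of compound 3 the swap gives a real change, a 4.6-fold lower number from compound 3 to compound 4 (0.66 log units; beyond the scatter), while on the core of compound 2 the same swap gave a step too small to read as any change, so a result from one core was a poor guide to the other here. This rests on one pair of compounds per core, so it shows that the outcome of this swap can depend on what sits on the other side of the core, but it does not show why, nor does it give a rule for other cores in the series.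

The compounds shown leave open how other groups at this same place on the core, such as an amine, a methyl group or a chloro group, would behave, and whether they too would differ between the two cores. They also leave open whether the larger step seen from compound 3 to compound 4 would hold if the other side of the core carried a different chain, such as a longer one or one ending in a carboxylic acid.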